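A few compounds are considered here, and "the series" means these few. Any claim that something is new, unique, unknown or untested is made for them only; others in the source may bear on it.

Measured so far, in a functional assay on Ehrlich cells (Mus musculus) for cytotoxicity, read by trypan blue exclusion, with a stated time of 2 h, tested at 50 ug/mL; on this read-out higher numbers stand for a stronger effect at the one concentration tested and lower numbers for a weaker effect:

compound 1, `N#CC1=C(N)N(c2ccc(S(N)(=O)=O)cc2)C2=C(C(=O)CCC2)C1c1ccc(Cl)cc1Cl`: 65%
compound 2, `CC(Cl)CC(=O)NC1=C(C#N)C(c2ccc(Cl)cc2Cl)C2=C(CCCC2=O)N1c1ccc(S(N)(=O)=O)cc1`: 55%
compound 3, `N#CC1=C(NC(=O)c2ccc([N+](=O)[O-])cc2)N(c2ccc(S(N)(=O)=O)cc2)C2=C(C(=O)CCC2)C1c1ccc(Cl)cc1Cl`: 50%

Compound 3 holds the lowest of the three numbers. Its nearest neighbour is compound 2, with a number 5 percentage points lower from compound 2 to compound 3 (within the scatter), so the two cannot be told apart; its furthest is compound 1, with a number 15 percentage points lower from compound 1 to compound 3 (beyond the scatter), a modest loss that does stand out. Both acylated amines sit under the free amine of compound 1, as a number 10 percentage points lower from compound 1 to compound 2 (within the scatter) also shows.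

Compound 4, `CC(=O)CC(=O)NC1=C(C#N)C(c2ccc(Cl)cc2Cl)C2=C(CCCC2=O)N1c1ccc(S(N)(=O)=O)cc1`, is the next variation on the acyl group: 2-oxopropyl in place of 4-nitrophenyl on a carbonyl carbon. Among the measured compounds shown here, the one measured step that bears on this kind of change is the swap of a chain for the aromatic group on the carbonyl carbon, a number 5 percentage points lower from compound 2 to compound 3 (within the scatter), which stayed within the scatter. With the acyl group again a short chain, compound 4 is expected to land close to compound 2 and compound 3, with no step beyond the scatter. The expected step is a number 5 percentage points higher from compound 3 to compound 4 (within the scatter). The estimate for compound 4 in this assay is 55%, with a range from 40% to 70%.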

Compound 4, a percentage reported as activity, at one concentration (the size of the read-out at that concentration, not a potency): 60%
Estimate against measurement, compound 4: 5 percentage points below; the range from low to high includes it.
By their numbers in this assay, from the lowest: compounds 3, 2, 4 and 1 (each within the scatter of the next, the first and the last beyond it).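

In this assay, among the compounds shown here, the swap of 4-nitrophenyl for 2-oxopropyl on the carbonyl carbon gives a number 10 percentage points higher from compound 3 to compound 4 (within the scatter) and so shows that the aromatic ring can leave this position with no step that stands out. Acetyl in place of 1-chloroethyl on the chain gives a number 5 percentage points higher from compound 2 to compound 4 (within the scatter) and the two chains cannot be told apart at this position. The step from the free amine is a number 5 percentage points lower from compound 1 to compound 4 (within the scatter) and so, of the three acylated amines, only compound 3 lies beyond the scatter of compound 1.

No measurement shown here accounts for these steps. From the compounds shown here alone, whether an amine, a carboxylic acid or a longer chain on this carbonyl carbon would give a step beyond the scatter remains open.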